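This account rests on a few compounds, and the source may have more. Where it says the series, first, only, none or still open, it means among the compounds named here.

Measured so far:
Compound 1, `Nc1ccc2c(c1)OCCCN2S(=O)(=O)c1ccc(-c2cnc(C3CC3)o2)cc1`: 56 nM
Compound 2, `O=S(=O)(c1ccc(-c2cnc(C3CC3)o2)cc1)N1CCOCc2ccccc21`: 175 nM
Compound 3, `O=S(=O)(c1ccc(-c2cnc(C3CC3)o2)cc1)N1CCCCc2ccccc21`: 38 nM

Of the compounds shown here, three sharing a sulfonyl-linked core have been tested in a functional assay on SK-OV-3 cells (Homo sapiens) for antiproliferative activity, read by MTT assay, with a stated time of 72 h; on this read-out lower numbers stand for stronger inhibition and higher numbers for weaker inhibition. In this assay compound 1 gives 56 nM, the second highest of the three numbers. Compound 3 gives 38 nM, and the gap between compound 1 and compound 3 lies within the usual scatter of the measurement, so the two are read as alike. Compound 2 gives 175 nM, a higher number than that of compound 1, and this gap lies beyond the scatter.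

The next compound, compound 4, is `O=S(=O)(c1ccc(-c2cnc(C3CC3)o2)cc1)N1CCCOc2cc(F)ccc21`. Compared with compound 1 it carries one change: fluoro in place of amino on an aromatic carbon. The change keeps the same core and the same ring count and exchanges one single atom on the fused benzene ring for another.

Going by the values given here, no pair of measured compounds shows what this exchange does, so the expectation rests on the spread seen among compounds 1, 2 and 3. The step from compound 1 to compound 4 is expected to be small, a 1.3-fold higher number from compound 1 to compound 4 (0.10 log units; within the scatter), and not beyond the scatter. Compound 4 is therefore estimated at 70 nM, within a range from 25 nM to 200 nM.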

Compound 4, half-maximal inhibitory concentration: 28 nM
Beside the measured number, compound 4's estimate is 2.5-fold (0.40 log units) above it, within the range that was stated.
By their numbers in this assay, from the lowest: compounds 4, 3 and 1 (each within the scatter of the next); then compound 2.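

In this assay the exchange gives a 2.0-fold lower number from compound 1 to compound 4 (0.30 log units; within the scatter), so compound 1 and compound 4 read as alike, with fluoro in place of amino on the aromatic carbon that is meta to a fused ring and para to a fused ring. Going by these compounds alone, this is the first comparison in the set in which two compounds differ in one place only, and it shows that the hydrogen-bond donor and hydrogen-bond acceptor counted on the amino group can leave this carbon without the number moving beyond the scatter. No measurement at hand speaks to the cause of this outcome.

The compounds shown leave open how this carbon would respond to plain hydrogen, or to a larger group such as chloro, methoxy or a carboxylic acid, so it remains unknown whether any group here matters at all. They also leave open whether fluoro would give a similar result on another carbon of the same ring, since a single exchange at one place cannot reveal a trend across the ring.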